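Ethoxy in place of tert-butyl on a carbonyl carbon

The compounds below may be only part of what the source reports. "The series", "measured", "known", "first", "only" and "open" are said of these compounds alone.

The series shares one core and varies the group on a carbonyl carbon. Within the data shown here, in a functional assay on HepG2 cells (Homo sapiens) for inhibition, read by scintillation counting, with a stated time of 2 h (on this read-out lower numbers stand for stronger inhibition and higher numbers for weaker inhibition), compound 3 `CCNC(=O)Nc1sc2ccccc2c1C(=O)N1CCN(C2CCN(C(=O)C(C)(C)C)CC2)CC1` gives 450 nM as the only number available so far. Compound 1 `CCNC(=O)Nc1sc2ccccc2c1C(=O)N1CCN(C2CCN(C(=O)C3CCN(C(C)=O)CC3)CC2)CC1` stands at "not determined" (no result reported) in the same read-out, and compound 2 `CCNC(=O)Nc1sc2ccccc2c1C(=O)N1CCN(C2CCN(C(=O)C(C)C)CC2)CC1` stands at "not determined" (no result reported) as well, so compound 3 cannot yet be ranked against any neighbour.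

Compound 4 `CCNC(=O)Nc1sc2ccccc2c1C(=O)N1CCN(C2CCN(C(=O)OCC)CC2)CC1` still awaits measurement. The change from compound 3 is ethoxy in place of tert-butyl on a carbonyl carbon and it puts ethoxy in place of tert-butyl on a carbonyl carbon, the other neighbour of that carbon being an amide-type nitrogen in a ring. The same difference reads as (tert-butyl)carbonyl to ethoxycarbonyl.

Among the measured compounds shown here, no measured step shows how strongly this assay responds to this group. The expectation rests on the value of compound 3 at 450 nM alone, and it is for no change beyond the scatter, with no direction favoured. The estimated step is a 1.1-fold lower number from compound 3 to compound 4 (0.05 log units; within the scatter). For the measured compounds named here, nothing measured so far points to a larger step. For compound 4 the estimate is 400 nM with an expected range from 100 nM to 1500 nM in this read-out.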

Compound 4, half-maximal inhibitory concentration: 228 nM
For compound 4 the middle estimate is 1.8-fold (0.24 log units) above the measured one; measured number inside the range.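

In this assay, the carbonyl carbon whose other neighbour is an amide-type nitrogen in a ring now has its first readable step (a 2.0-fold lower number from compound 3 to compound 4 (0.30 log units; within the scatter)). This step shows that the position can carry either an all-carbon tert-butyl or an oxygen-linked ethoxy, with the two compounds remaining within the scatter of each other, so the exchange of (tert-butyl)carbonyl for ethoxycarbonyl gives no sign of a real effect on this read-out, even though it brings in a hydrogen-bond acceptor and leaves one heavy atom fewer. No supporting evidence is available to explain this outcome or to tie it to any property of either group.

Steps involving compound 1 and compound 2 cannot be read, so this single pair is all that speaks for the position, and it cannot show how far the tolerance extends. On these data alone, it remains open whether a dimethylamino group on the same carbonyl carbon, or a longer chain such as butoxy in place of ethoxy, would shift the read-out beyond the scatter.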